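Changing the amide end of compound 2

The compounds below may be only part of what the source reports. "The series", "measured", "known", "first", "only" and "open" are said of these compounds alone.

Measured in a functional assay on U-937 cells (Homo sapiens) for antiproliferative activity, read by MTT assay, with a stated time of 24 h; a higher number here means a weaker inhibitor, a lower number a stronger inhibitor:
- compound 1 `CCCCNC(=O)COc1ccc(C(=O)c2c(CCCC)oc3ccccc23)cc1`: 22800 nM
- compound 2 `CCCCc1oc2ccccc2c1C(=O)c1ccc(OCC(=O)N[C@@H](C)c2ccccc2)cc1`: 33800 nM

Among the compounds with values here, only these two compounds have numbers so far, and they lie within the scatter of each other, so neither stands apart. Compound 3 `CCCCc1oc2ccccc2c1C(=O)c1ccc(OCCCC(=O)N2CCOCC2)cc1` differs from compound 2 by one change: 2-((morpholin-4-yl)carbonyl)ethyl in place of (1-phenylethyl)carbamoyl on a saturated chain carbon bound to an oxygen on an aromatic ring. In words, 2-((morpholin-4-yl)carbonyl)ethyl sits in place of (1-phenylethyl)carbamoyl on a saturated chain carbon bound to an oxygen on an aromatic ring.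

Within the data shown here, one measured step bears on this: a 1.5-fold higher number from compound 1 to compound 2 (0.17 log units; within the scatter), which swapped butyl for 1-phenylethyl on an amide-type nitrogen. It is only a loose guide, since it does not cover the new group. Still, no shift beyond the scatter is expected in this assay. The expected size is a 1.2-fold lower number from compound 2 to compound 3 (0.08 log units; within the scatter). For compound 3 the estimated value is 28000 nM, with an expected range of 12000 nM to 65000 nM.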

Compound 3, half-maximal inhibitory concentration: 21400 nM
Beside the measured number, compound 3's estimate is 1.3-fold (0.12 log units) above it; low and high end bracket the measured number.
By their numbers in this assay, from the lowest: compounds 3, 1 and 2 (each within the scatter of the next).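

Placing 2-((morpholin-4-yl)carbonyl)ethyl on a saturated chain carbon bound to an oxygen on an aromatic ring gives a 1.6-fold lower number from compound 2 to compound 3 (0.20 log units; within the scatter) in this assay, and the same place gives a 1.1-fold lower number from compound 1 to compound 3 (0.03 log units; within the scatter) as well. The earlier pair differed only in the group on an amide-type nitrogen, whereas this change brings in a non-aromatic ring with 2 hetero atoms and leaves 0 hydrogen-bond donors in the entering group, yet this assay separates compound 3 from neither compound 1 nor compound 2. No measurement in hand accounts for this lack of separation.

The ethyl part and the morpholin-4-yl ring enter together in one step, so their separate shares cannot be read. On these data alone, whether a different end on the chain, such as a carboxylic acid or an amine, would move the number beyond the scatter remains open.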